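From a Propyl Ester to an Oxan-3-yl Ester

This account rests on a few compounds, and the source may have more. Where it says the series, first, only, none or still open, it means among the compounds named here.

In an ADME assay on a cell-free system (plasma, Homo sapiens) for metabolic stability, read by LC-MS (a higher number here means that the compound lasts longer, a lower number that the compound disappears faster), compound 3 `CCCOC(=O)c1cccc(-c2cc(C(=O)Nc3ccncc3F)ccc2CN)c1` gives 0.317 h, the highest number of this small set. Compound 2 `NCc1ccc(C(=O)Nc2ccncc2F)cc1-c1cccc(C(=O)OCC2CCCCO2)c1` gives 0.117 h. Compound 1 `NCc1ccc(C(=O)Nc2ccncc2F)cc1-c1cccc(C(=O)OCC2CCCO2)c1` returns only a limit of the assay, < 0.0834 h. Compound 4 `NCc1ccc(C(=O)Nc2ccncc2F)cc1-c1cccc(C(=O)OC2CCCOC2)c1` differs from compound 3 as follows: oxan-3-yl in place of propyl on an oxygen next to a carbonyl group. In short, oxan-3-yl stands in place of propyl on an oxygen next to a carbonyl group. The closest evidence comes from two ring-bearing esters, which both fall short of the open-chain compound 3: a 2.7-fold higher number from compound 2 to compound 3 (0.43 log units; beyond the scatter), and an at least 3.8-fold higher number from compound 1 to compound 3 (0.57 log units; beyond the scatter). Their rings sit on a saturated chain carbon, so the comparison is indirect, and only a modest drop is expected. The expected change is a 1.9-fold lower number from compound 3 to compound 4 (0.27 log units; within the scatter). Compound 4 is estimated at 0.17 h, with an expected range of 0.085 h to 0.5 h.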

Compound 4, half-life: 0.3 h
Compound 4: the middle estimate sits 1.8-fold (0.25 log units) below what was measured; the range from low to high includes it.
By their numbers in this assay, from the lowest: compound 2; then compounds 4 and 3 (each within the scatter of the next). At a limit, below all of these: compound 1.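

With oxan-3-yl on the oxygen, this ring-bearing ester cannot be told apart from the propyl ester in this assay, with a 1.1-fold lower number from compound 3 to compound 4 (0.02 log units; within the scatter). The two esters whose rings sit on a saturated chain carbon fall short of it, with a 2.6-fold higher number from compound 2 to compound 4 (0.41 log units; beyond the scatter) and an at least 3.5-fold higher number from compound 1 to compound 4 (0.55 log units; beyond the scatter), so the presence of a ring alone does not set the number. The number for compound 1 is a limit of the assay, so its step is a floor: the limit of < 0.0834 h in this assay, at which 1 of the 4 values shown sits.

Still open, going by these compounds, is how a ring carrying an amine, such as piperidin-4-yl, or a longer chain, such as butyl, would read on this oxygen.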